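This account rests on a few compounds, and the source may have more. Where it says the series, first, only, none or still open, it means among the compounds named here.

Measured in an ADME assay on HepG2 cells (Homo sapiens) for inhibition, read by fluorescence and resazurin assay, with a stated time of 72 h; a lower number here means a stronger inhibitor, a higher number a weaker inhibitor:

- Compound 1 `NS(=O)(=O)c1cccc(Nc2nccc(Nc3ccc4nc[nH]c4c3)n2)c1`: > 25000 nM (a limit of the assay, not a number)
- Compound 2 `Cc1cccc(Nc2nccc(Nc3ccc4nc[nH]c4c3)n2)c1`: 20000 nM
- Compound 3 `CN1CCN(c2cccc(Nc3nccc(Nc4ccc5cn[nH]c5c4)n3)c2)CC1`: 6700 nM

Of the two exact numbers, compound 3 has the lower one, and compound 2 the higher. Compound 4 `CN1CCN(c2cccc(Nc3nccc(Nc4ccc5nc[nH]c5c4)n3)c2)CC1` has the same atoms as compound 3, joined differently: 1H-benzimidazol-6-yl in place of 1H-indazol-6-yl on a nitrogen on an aromatic ring. Going by the values given here, the only measured step, an at least 1.2-fold lower number from compound 1 to compound 2 (0.09 log units; that floor lies within the scatter), exchanges sulfamoyl for methyl, a different change elsewhere in the molecule. Among the compounds with values here, compound 1 and compound 2 carry 1H-benzimidazol-6-yl, but no measured pair isolates this exchange. The expected result is a 1.2-fold higher number from compound 3 to compound 4 (0.08 log units; within the scatter), so no step beyond the scatter is expected in this assay. For compound 4 the estimate is 8000 nM, with an expected range of 3000 nM to 20000 nM.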

Compound 4, half-maximal inhibitory concentration: 11000 nM
Compound 4: the middle estimate sits 1.4-fold (0.14 log units) below what was measured, within the range that was stated.
By their numbers in this assay, from the lowest: compounds 3, 4 and 2 (each within the scatter of the next, the first and the last beyond it). At a limit, above all of these: compound 1.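

In this assay the exchange of 1H-indazol-6-yl for 1H-benzimidazol-6-yl on this nitrogen reads a 1.6-fold higher number from compound 3 to compound 4 (0.22 log units; within the scatter) and so gives the two groups no measurable separation at this position. Going by these compounds alone, with 1H-benzimidazol-6-yl kept, 4-methylpiperazin-1-yl in place of methyl reads a 1.8-fold lower number from compound 2 to compound 4 (0.26 log units; within the scatter) and in place of sulfamoyl reads an at least 2.2-fold lower number from compound 1 to compound 4 (0.35 log units; beyond the scatter) as the only step here beyond the scatter. The value of compound 1 is a limit of the assay, not a number, and that last step is only a floor: the limit of > 25000 nM in this assay, at which 1 of the 4 values shown sits.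

From the compounds shown here alone, what a morpholin-4-yl group in place of 4-methylpiperazin-1-yl, or a plain phenyl in place of 1H-benzimidazol-6-yl, would read in this assay stays open.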